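Notes on amide variation in a dihydroxyheptanoic acid series

The source may hold more compounds than are shown below. What is called first, only, known or untested is meant among the compounds shown, and "the series" means these compounds.

compound 1 `Cc1ccc(CNC(=O)c2nn(-c3ccc(F)cc3)c(OC[C@@H](O)C[C@@H](O)CC(=O)O)c2C(C)C)cc1`: 15 nM
compound 2 `CC(C)c1c(C(=O)N(C)Cc2cccc(F)c2)nn(-c2ccc(F)cc2)c1OC[C@@H](O)C[C@@H](O)CC(=O)O`: 14 nM
compound 3 `CC(C)c1c(C(=O)N(C)Cc2ccc(F)c(F)c2)nn(-c2ccc(F)cc2)c1OC[C@@H](O)C[C@@H](O)CC(=O)O`: 5.7 nM

All three were run in an assay on microsomes from liver for inhibition of 3-hydroxy-3-methylglutaryl-coenzyme A reductase (Rattus norvegicus); a lower number here means a stronger inhibitor, a higher number a weaker inhibitor. Compound 3 stands lowest of the three: the steps of a 2.6-fold lower number from compound 1 to compound 3 (0.42 log units; beyond the scatter) and a 2.5-fold lower number from compound 2 to compound 3 (0.39 log units; beyond the scatter) both lie beyond the scatter, whereas a 1.1-fold lower number from compound 1 to compound 2 (0.03 log units; within the scatter) does not. Compound 4 `CC(C)c1c(C(=O)N(C)[C@H](C)c2ccccc2)nn(-c2ccc(F)cc2)c1OC[C@@H](O)C[C@@H](O)CC(=O)O` carries 1-phenylethyl in place of 3,4-difluorobenzyl on an amide-type nitrogen. The fluorines of compound 3 leave and a ring-bearing group with a defined stereocentre enters. Within the data shown here, the only measured step that bears on this is a 2.5-fold lower number from compound 2 to compound 3 (0.39 log units; beyond the scatter), a modest gain on adding one fluoro; undoing fluorination should modestly raise the number. Among the measured compounds shown here, the added branching has no precedent and adds uncertainty. Compound 4 is therefore expected at about 15 nM (range 5 nM to 45 nM), an estimated step of a 2.6-fold higher number from compound 3 to compound 4 (0.42 log units; beyond the scatter).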

Compound 4, half-maximal inhibitory concentration: 21 nM
For compound 4 the middle estimate is 1.4-fold (0.15 log units) below the measured one; the range from low to high includes it.
By their numbers in this assay, from the lowest: compound 3; then compounds 2, 1 and 4 (each within the scatter of the next).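

The step of a 3.7-fold higher number from compound 3 to compound 4 (0.57 log units; beyond the scatter) shows that 1-phenylethyl on the amide-type nitrogen does not hold the standing of 3,4-difluorobenzyl, while a 1.5-fold higher number from compound 2 to compound 4 (0.18 log units; within the scatter) and a 1.4-fold higher number from compound 1 to compound 4 (0.15 log units; within the scatter) both lie within the scatter. In this assay compound 3 thus remains alone, and a group with a defined stereocentre and no fluorine sits level with compounds 1 and 2. Nothing at hand accounts for this step.

Plain benzyl and the opposite stereocentre of 1-phenylethyl on this nitrogen remain open. The shares of the lost fluorines and the added methyl branch in this step therefore stay unresolved.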